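The compounds below may be only part of what the source reports. "The series", "measured", "known", "first", "only" and "open" are said of these compounds alone.

Measured in a functional assay on HCT-116 cells (Homo sapiens) for inhibition, read by sulforhodamine B assay, with a stated time of 48 h; a lower number here means a stronger inhibitor of growth, a higher number a weaker inhibitor of growth:
- compound 1 `Cc1cn([C@H]2C[C@H](CC3=CC(=O)C(=O)C=C3)[C@@H](CO[Si](C)(C)C(C)(C)C)O2)c(=O)[nH]c1=O`: no result reported
- compound 2 `COc1ccc(C2([C@H]3C[C@H](n4cc(C)c(=O)[nH]c4=O)O[C@@H]3CO[Si](C)(C)C(C)(C)C)SCCCS2)cc1OC`: 3630 nM

Among the measured compounds shown here, compound 2 holds the only number so far, so it cannot be ranked against anything. For the measured compounds named here, compound 1 offers no comparison, and no step between measured compounds exists to serve as a guide.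

The next compound to be read is compound 3 `COc1ccc(C2([C@H]3C[C@@H](n4cc(C)c(=O)[nH]c4=O)O[C@@H]3CO[Si](C)(C)C(C)(C)C)SCCCS2)cc1OC`. Its relation to compound 2 is purely one of configuration: the two compounds have the same atoms and bonds and differ only in configuration as drawn: 1 of 3 stereo elements differ; a stereocentre at a saturated ring carbon is drawn R in compound 2 and S in compound 3. No atoms leave or enter, and the single stereocentre at a saturated ring carbon drawn R in compound 2 is drawn S in compound 3.

Going by the values given here, the data hold no example of what such an inversion does in this assay. The expectation therefore starts from compound 2 at 3630 nM and leans only modestly toward a weaker inhibitor of growth, with a result inside the usual scatter entirely possible. The expected move is a 1.4-fold higher number from compound 2 to compound 3 (0.14 log units; within the scatter), and this remains an uncertain estimate.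

For compound 3 the estimated value is 5000 nM, with an expected range of 2000 nM to 15000 nM.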

Compound 3, concentration for 50% growth inhibition: 5750 nM
Compound 3: the middle estimate sits 1.2-fold (0.06 log units) below what was measured; measured number inside the range.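

In this assay, the inversion of a stereocentre at a saturated ring carbon, drawn R in compound 2 and S in compound 3, gives a 1.6-fold higher number from compound 2 to compound 3 (0.20 log units; within the scatter). Among the compounds shown here, this is the first matched comparison, and it shows that this R and S pair is not separated by this read-out: at this position, the configuration as drawn gives no measurable preference. The pair is a clean test of this single change, with no other structural difference to weigh in reading the step: the fact that compounds 2 and 3 differ only in the configuration as drawn

The compounds shown leave open whether the same inversion would stay within the scatter if the tert-butyldimethylsilyl ether were replaced by a free hydroxyl group or an amine, and what the other two stereo elements contribute in this assay. For the compounds shown here, with only one matched pair available, nothing about this inversion can be extended beyond compound 2 and compound 3, and the bearing of the remaining parts of these structures on growth inhibition is still untested in the compounds at hand.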